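The compounds below may be only part of what the source reports. "The series", "measured", "known", "first", "only" and "open" are said of these compounds alone.

Measured so far:
compound 1 `Cc1ccccc1-c1ccc2[nH]ncc2c1` — 7810 nM
compound 2 `FC(F)(F)c1ccccc1-c1ccc2[nH]ncc2c1` — 164 nM
compound 3 `Fc1cccc(-c2ccc3[nH]ncc3c2)c1C(F)(F)F` — 8900 nM

In an assay on CHO-TREX cells for antagonist activity at transient receptor potential cation channel subfamily A member 1 (Homo sapiens), read by FLIPR and calcium flux, with a stated time of 10 min (a higher number here means a weaker inhibitor, a lower number a stronger inhibitor), compound 2 holds the lowest number of the three. The step of a 48-fold lower number from compound 1 to compound 2 (1.68 log units; beyond the scatter) takes it well away from compound 1, and the step of a 54-fold higher number from compound 2 to compound 3 (1.73 log units; beyond the scatter) puts compound 3 back near compound 1.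

Compound 4 `Fc1cc2[nH]ncc2cc1-c1ccccc1C(F)(F)F` is not yet measured. Against compound 2 the change is fluoro in place of hydrogen on an aromatic carbon, here on the shared core rather than on the pendant ring. For the measured compounds named here, the one measured step of the same kind, a 54-fold higher number from compound 2 to compound 3 (1.73 log units; beyond the scatter), concerns the pendant ring and was large and adverse. Whether a fluoro on the core behaves the same is not shown by any measured pair, so the expectation leans on that single step only in part.

For compound 4 in this assay a weaker inhibition than compound 2 is expected, by a step of about a 3.7-fold higher number from compound 2 to compound 4 (0.56 log units; beyond the scatter), smaller than the measured loss seen for compound 3. The estimate for compound 4 is 600 nM, with a range from 150 nM to 3000 nM.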

Compound 4, half-maximal inhibitory concentration: 48 nM
Beside the measured number, compound 4's estimate is 13-fold (1.10 log units) above it, outside the stated range (below it).
By their numbers in this assay, from the lowest: compound 4; then compound 2; then compounds 1 and 3 (each within the scatter of the next).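

In this assay fluoro in place of hydrogen on an aromatic carbon of the shared core, ortho to a large group, gives a 3.4-fold lower number from compound 2 to compound 4 (0.53 log units; beyond the scatter) and so shows that this position accepts the change with a modest gain. The same kind of change on the pendant ring gave a 54-fold higher number from compound 2 to compound 3 (1.73 log units; beyond the scatter) and, as far as these two steps go, the direction of the step depends on where the fluoro sits. No measurement here bears on the reason for this difference.

From the compounds shown here alone, whether chloro, methoxy or an amine at this position of the core would keep the gain remains open. Also open, going by these compounds, are fluoro on the other aromatic carbons of the core and whether the gain holds with methyl in place of trifluoromethyl on the pendant ring.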